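The compounds below may be only part of what the source reports. "The series", "measured", "known", "first", "only" and "open" are said of these compounds alone.

Measured compounds:
compound 1 `N#Cc1ccc(NC(=O)COc2ccnc(Nc3ccc(C#N)cc3)n2)cc1` — > 337000 nM (a limit of the assay)
compound 2 `N#Cc1ccc(Nc2nccc(OCC(=O)Nc3ccc(C#N)cc3F)n2)cc1` — > 321000 nM (a limit of the assay)
compound 3 `Cc1cc(OCC(=O)Nc2ccc(C#N)cc2)nc(Nc2ccc(C#N)cc2)n1` — > 325000 nM (a limit of the assay)

In an ADME assay on MT4 cells (Homo sapiens) for cytotoxicity, read by MTT assay, with a stated time of 5 days (on this read-out lower numbers stand for higher toxicity in this test and higher numbers for lower toxicity in this test), compound 1 reaches only the limit > 337000 nM. Compound 2 likewise stops at the limit > 321000 nM. Compound 3 too returns the limit > 325000 nM. The change from compound 1 to compound 2 is fluoro in place of hydrogen on an aromatic carbon; its step that the two limits leave unreadable from compound 1 to compound 2 cannot be sized because the limit of > 337000 nM in this assay, at which 1 of the 3 values shown sits, and the limit of > 321000 nM in this assay, at which 1 of the 3 values shown sits, are both limits. The two cores differ by methyl in place of hydrogen on an aromatic carbon; here again a step that the two limits leave unreadable from compound 1 to compound 3 is unreadable because the limit of > 325000 nM in this assay, at which 1 of the 3 values shown sits, is also a limit. Compound 4 `Cc1cc(OCC(=O)Nc2ccc(C#N)cc2F)nc(Nc2ccc(C#N)cc2)n1` differs from compound 3 by fluoro in place of hydrogen on an aromatic carbon, the same change at the same place as before. In this assay the step that the limit leaves unreadable from compound 3 to compound 4 is expected, resting on the unreadable step that the two limits leave unreadable from compound 1 to compound 2, which left compound 2 at a limit. Compound 4 is thus estimated at 330000 nM, with a range from 150000 nM to 450000 nM, most probably again as a limit.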

Compound 4, half-maximal cytotoxic concentration: > 310000 nM
Compound 4 ended at the assay's limit; the forecaster's own chance of this, stated with the estimate: 85%; the middle value lies beyond the limit too.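

In this assay, going by these compounds alone, compound 4 gives > 310000 nM, a limit of the assay, so no step from compound 2 or compound 3 to compound 4 can be read. Going by these compounds, with all four values limits, whether fluoro or methyl in place of hydrogen changes the read-out at all stays open.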